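Swapping methoxy for chloro on the pendant aryl ring

The compounds below may be only part of what the source reports. "The series", "measured", "known", "first", "only" and "open" are said of these compounds alone.

Measured compounds:
compound 1 `COc1ccc(C2=NN(C3=NC(=O)/C(=C4\C(=O)Nc5ccccc54)S3)C(c3ccc(OC)cc3)C2)cc1` — 100000 nM
compound 2 `COc1ccc(C2=NN(C3=NC(=O)/C(=C4\C(=O)Nc5ccc(Br)cc54)S3)C(c3ccc(OC)cc3)C2)cc1` — 270 nM
compound 3 `COc1ccc(C2=NN(C3=NC(=O)/C(=C4\C(=O)Nc5ccc(Cl)cc54)S3)C(c3ccc(OC)cc3)C2)cc1` — 250 nM

In a functional assay on cells (Cancer cell lines, Homo sapiens) for cytotoxicity, read by sulforhodamine B assay, with a stated time of 48 h (a lower number here means a stronger inhibitor of growth, a higher number a weaker inhibitor of growth), compound 3 has the lowest number of the three. It sits far from compound 1, as a 400-fold lower number from compound 1 to compound 3 (2.60 log units; beyond the scatter) shows, a step matched by a 370-fold lower number from compound 1 to compound 2 (2.57 log units; beyond the scatter). Against compound 2 it is not separated, since a 1.1-fold lower number from compound 2 to compound 3 (0.03 log units; within the scatter) lies within the scatter.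

Compound 4 `COc1ccc(C2=NN(C3=NC(=O)/C(=C4\C(=O)Nc5ccc(Cl)cc54)S3)C(c3ccc(Cl)cc3)C2)cc1` differs from compound 3 in a different part of the molecule: chloro in place of methoxy on an aromatic carbon. For the measured compounds named here, no measured step touches this ring; the steps that were measured all concern a halogen on the other aromatic ring of the shared core, and they show large effects there but say nothing about this position. The closest hint is that compounds 2 and 3 show chloro and bromo giving numbers within the scatter of each other on the core ring.

Going by the values given here, with no step bearing directly on the change, compound 4 is expected to stay close to compound 3, with an expected step of a 1.2-fold higher number from compound 3 to compound 4 (0.08 log units; within the scatter) in this assay. The estimate for compound 4 is 300 nM, ranging from 100 nM to 900 nM.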

Compound 4, concentration for 50% growth inhibition: 270 nM
Compound 4: the middle estimate sits 1.1-fold (0.05 log units) above what was measured; low and high end bracket the measured number.
By their numbers in this assay, from the lowest: compounds 3, 2 and 4 (each within the scatter of the next); then compound 1.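

In this assay, for the compounds shown here, the change from 4-methoxyphenyl to 4-chlorophenyl gives a 1.1-fold higher number from compound 3 to compound 4 (0.03 log units; within the scatter), the first measured step on this ring. Between these two groups, then, this position does not separate the compounds, whereas adding the halogen on the other aromatic ring gave a 400-fold lower number from compound 1 to compound 3 (2.60 log units; beyond the scatter). Nothing at hand offers a reason for this flat result.

From the compounds shown here alone, the step rests on a single pair carrying chloro on the core ring, so it remains open whether the same swap would stay within the scatter with bromo there, as in compound 2, or with hydrogen, as in compound 1. Going by these compounds, it is also open whether an amine, a carboxylic acid or a longer alkoxy chain at this position would leave the number as little changed as chloro does.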